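Longer chains at the sulfonyl urea: from compound 3 to compound 4

The source may report more compounds than this note shows. Statements on the series, on what has been measured and on what is new or still open speak of the compounds shown alone.

Measured compounds:
Compound 1, `CCCCCCCCCCS(=O)(=O)NC(=O)Nc1c(C(C)C)cccc1C(C)C`: 13600 nM
Compound 2, `CCCCCCCCCCCCS(=O)(=O)NC(=O)Nc1c(C(C)C)cccc1C(C)C`: 3300 nM
Compound 3, `CCCCCCCCCCCCCCS(=O)(=O)NC(=O)Nc1c(C(C)C)cccc1C(C)C`: 940 nM

In an assay on microsomes from liver for inhibition of sterol O-acyltransferase 1 (Rattus norvegicus) (on this read-out lower numbers stand for stronger inhibition and higher numbers for weaker inhibition), compound 3 gives the lowest of the three numbers, with compound 2 as its nearest neighbour and compound 1 furthest away. The three compounds share one core and differ only in the length of the saturated chain on the sulfonyl sulfur.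

Compound 4, `CCCCCCCCCCCCCCCCS(=O)(=O)NC(=O)Nc1c(C(C)C)cccc1C(C)C`, has not yet been measured. It differs from compound 3 by ethyl in place of hydrogen on a saturated chain carbon, ten or more bonds along the chain from a sulfonyl sulfur.

Two measured steps carry exactly this change: a 4.1-fold lower number from compound 1 to compound 2 (0.62 log units; beyond the scatter) and a 3.5-fold lower number from compound 2 to compound 3 (0.55 log units; beyond the scatter). The combined step a 14-fold lower number from compound 1 to compound 3 (1.16 log units; beyond the scatter) confirms that each lengthening has so far lowered the number in this assay beyond the scatter, with the second step slightly smaller than the first. Among the measured compounds shown here, a further lowering for compound 4 is therefore expected, of a size near the earlier steps but possibly smaller; compound 4 is estimated to show a 3.0-fold lower number from compound 3 to compound 4 (0.48 log units; beyond the scatter). Compound 4 is expected to give about 310 nM in this assay, within 100 nM to 900 nM.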

Compound 4, half-maximal inhibitory concentration: 1270 nM
Estimate against measurement, compound 4: 4.1-fold (0.61 log units) below, outside the stated range (above it).
By their numbers in this assay, from the lowest: compounds 3 and 4 (each within the scatter of the next); then compound 2; then compound 1.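

In this assay, the ethyl change that separated the shorter chains no longer separates the two longest: a 1.4-fold higher number from compound 3 to compound 4 (0.13 log units; within the scatter). The longest chain still stands apart from the shorter ones, with a 2.6-fold lower number from compound 2 to compound 4 (0.41 log units; beyond the scatter) and an 11-fold lower number from compound 1 to compound 4 (1.03 log units; beyond the scatter), so the lowering seen up to compound 3 does not carry on to compound 4. The same change therefore has no fixed size on this saturated chain: the same change on two cores in this assay, a 4.1-fold lower number (0.62 log units; beyond the scatter) from compound 1 to compound 2 and a 1.4-fold higher number (0.13 log units; within the scatter) from compound 3 to compound 4, 5.6-fold (0.75 log units) apart, beyond the scatter of two such steps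

The compounds shown leave open whether a chain longer than that of compound 4 would stay level with it or give a higher number. They also leave open how a chain ending in an amine or a carboxylic acid would read in this assay.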